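Cytotoxicity notes on the lignan lactone ether series

A few compounds are considered here, and "the series" means these few. Any claim that something is new, unique, unknown or untested is made for them only; others in the source may bear on it.

Among the compounds with values here, compound 1, `COc1ccc(C[C@H]2COC(=O)[C@@H]2Cc2ccc(OCc3cn(-c4ccc(Br)cc4)nn3)c(OC)c2)cc1OC`, is the only member of the series with a full number in an ADME assay on HeLa cells (Homo sapiens) for cytotoxicity, read by MTT assay; on this read-out higher numbers stand for weaker inhibition and lower numbers for stronger inhibition; there compound 1 gives 128000 nM. Compound 2, `COc1ccc(C[C@H]2COC(=O)[C@@H]2Cc2ccc(OCc3cn(Cc4ccccc4F)nn3)c(OC)c2)cc1OC`, reaches only a limit of the assay in this assay, where compound 2 gives >= 600000 nM. Within the data shown here, the one measured step, an at least 4.6-fold higher number from compound 1 to compound 2 (0.67 log units; beyond the scatter), is therefore anchored on the limit side by the limit of >= 600000 nM in this assay, at which 1 of the 2 values shown sits.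

Compound 3, `COc1ccc(C[C@H]2COC(=O)[C@@H]2Cc2ccc(OCC(=O)N3CCCCC3)c(OC)c2)cc1OC`, differs from compound 1 in the same region of the molecule: (piperidin-1-yl)carbonyl in place of 1-(4-bromophenyl)-1H-1,2,3-triazol-4-yl on a saturated chain carbon bound to an oxygen on an aromatic ring. The change goes further than the step from compound 1 to compound 2, since the triazole and the halogenated ring both leave and a saturated amide takes their place. Among the measured compounds shown here, the only bearing evidence is that exchanging the substituent on the aromatic nitrogen already pushed the number to the limit; a step of comparable or larger size in the same direction, toward weaker inhibition, is the expectation for this assay. For compound 3 a value of 450000 nM is estimated, between 150000 nM and 1200000 nM, which means an expected step of a 3.5-fold higher number from compound 1 to compound 3 (0.55 log units; beyond the scatter), with a real chance that only a limit is reported.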

Compound 3, half-maximal inhibitory concentration: 293000 nM
Compound 3: the middle estimate sits 1.5-fold (0.19 log units) above what was measured, and the stated range covers the measured number.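

Taking out the whole 1-(4-bromophenyl)-1H-1,2,3-triazol-4-yl group and putting (piperidin-1-yl)carbonyl in its place still gives a full number in this assay, with a 2.3-fold higher number from compound 1 to compound 3 (0.36 log units; beyond the scatter). With both triazole rings gone, the change at this position goes the same way as the exchange on the aromatic nitrogen in compound 2, so compound 1 holds the lowest number of the three compounds shown and both changes lead to weaker inhibition. Compound 2 remains the only compound whose value is a limit and not a number: the limit of >= 600000 nM in this assay, at which 1 of the 3 values shown sits.

The step to compound 3 changes the triazole, the 4-bromophenyl ring and the bromine in one move, so the compounds shown do not tell which of these parts goes with the lower number of compound 1. A plain phenyl on the triazole would separate the bromine from the ring, while a carboxylic acid or an amine on the saturated chain carbon would show whether the number at this position follows anything beyond the loss of the triazole.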